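Swapping a Methoxyphenylethyl Arm for a Phenylethynyl Arm

This account rests on a few compounds, and the source may have more. Where it says the series, first, only, none or still open, it means among the compounds named here.

Of the compounds shown here, two have been measured so far. In a functional assay on cells (T-cell line, Homo sapiens) for inhibition (a lower number here means a stronger inhibitor, a higher number a weaker inhibitor), compound 2 `COc1ccccc1CCCN1CCC(COC(c2ccccc2)c2ccccc2)CC1` gives 2400 nM, and in this assay compound 1 `COc1ccc(CCCN2CCC(COCC3CCCCC3)CC2)cc1` gives 3000 nM. Compound 2 holds the smaller of the two numbers, but the gap to compound 1 lies within the usual scatter, so the two cannot be ranked. Compound 3 `C(#Cc1ccccc1)CN1CCC(COC(c2ccccc2)c2ccccc2)CC1` has not been measured; it differs from compound 2 by 2-phenylethynyl in place of 2-(2-methoxyphenyl)ethyl on a saturated chain carbon bound to an amine nitrogen in a ring. For the measured compounds named here, no measured pair shows a change of this kind, so the step is expected to be modest and of uncertain direction, estimated as a 1.3-fold higher number from compound 2 to compound 3 (0.10 log units; within the scatter). For compound 3 the estimate is 3000 nM, expected to fall between 800 nM and 12000 nM.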

Compound 3, half-maximal inhibitory concentration: > 20000 nM
Compound 3 gave a limit, no number (the forecaster's own chance of this, stated with the estimate: 10%); at least 6.6-fold (0.82 log units) between middle value and limit.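

For the compounds shown here, at this position, on a saturated chain carbon bound to an amine nitrogen in a ring, the arm matters: 2-phenylethynyl in place of 2-(2-methoxyphenyl)ethyl gives an at least 8.3-fold higher number from compound 2 to compound 3 (0.92 log units; beyond the scatter) in this assay and is the first change here read beyond the scatter. The value of compound 3 is a limit, not a number: the limit of > 20000 nM in this assay, at which 1 of the 3 values shown sits.

The compounds shown do not separate the effect of the triple bond from that of losing the methoxy group. As far as these compounds go, a saturated 2-phenylethyl arm without the methoxy group would sit between the two, and how it would read remains open.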